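Cyanobenzyl Ether Against Phenethyl Ether at the Same Position

A few compounds are considered here, and "the series" means these few. Any claim that something is new, unique, unknown or untested is made for them only; others in the source may bear on it.

Compound 1 `Cc1nn(-c2ncnc3nc[nH]c23)c2c1C(C(=O)NCc1ccc(F)cc1)CC(=O)N2` and compound 2 `Cc1nn(-c2ncnc3nc[nH]c23)c2c1C(OCc1ccc(C#N)cc1)CC(=O)N2` share a core and differ in the group attached to its saturated chain carbon. In a functional assay on HEK293 cells for agonist activity at G-protein coupled receptor 39 (Homo sapiens), read by scintillation proximity assay and inositol phosphate accumulation, with a stated time of 75 min (a higher number here means that more compound is needed for the effect, a lower number that less compound is needed), compound 1 gives 1220 nM. In this assay compound 2 gives 60 nM, the lowest of the two numbers, and the gap to compound 1 lies beyond the scatter. Compound 3 `Cc1nn(-c2ncnc3nc[nH]c23)c2c1C(OCCc1ccccc1)CC(=O)N2` has not yet been measured in this assay. It differs from compound 2 in a single place: benzyl in place of 4-cyanophenyl on a saturated chain carbon bound to an oxygen on a saturated carbon. For the measured compounds named here, no step between two measured compounds differing in one place is available, so the size of this change has no direct anchor here. The step from compound 2 to compound 3 is expected to be a moderate rise, a 3.3-fold higher number from compound 2 to compound 3 (0.52 log units; beyond the scatter), a little beyond the scatter. Compound 3 is therefore estimated at 200 nM, within a range from 60 nM to 700 nM.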

Compound 3, half-maximal effective concentration: 40 nM
Compound 3: middle estimate off by 5.0-fold (0.70 log units), on the high side; measured number outside the range, below it.
By their numbers in this assay, from the lowest: compounds 3 and 2 (each within the scatter of the next); then compound 1.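

For the compounds shown here, the exchange of (4-cyanobenzyl)oxy for phenethyloxy at this position comes to a 1.5-fold lower number from compound 2 to compound 3 (0.18 log units; within the scatter) in this assay, the first step in one place available here. The two ethers therefore cannot be told apart in this read-out: the 4-cyanobenzyl group, with its nitrile, can give way to phenethyl, which carries no nitrile, and the number stays within the usual scatter. So at this position, the nitrile is not required for a number of this size, at least on the phenethyl ether. Nothing given here accounts for this outcome.

Because the nitrile leaves and the chain changes in the same step, the compounds shown do not separate the two changes; a plain benzyl ether or a phenethyl ether carrying a nitrile would do so. On these data alone, how a longer chain, or an amine on the phenyl ring, would read also remains open.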